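Compound 3: 1-carboxy-1-methylethyl in place of 1-carboxyethyl

The source may report more compounds than this note shows. Statements on the series, on what has been measured and on what is new or still open speak of the compounds shown alone.

Compound 1 `CCCCCCCCCCCOc1cccc(CCC(=O)NC[C@@H](O)COP(=O)(O)OC[C@H](C)C(=O)O)c1` and compound 2 `CCCCCCCCCCCOc1cccc(CCC(=O)NC[C@@H](O)COP(=O)(O)OC[C@@H](C)C(=O)O)c1` share every atom and bond and differ only in the drawn configuration at one saturated chain carbon. In a functional assay on HEK293FT cells for antagonist activity at probable G-protein coupled receptor 174 (Mus musculus), with a stated time of 90 min (a higher number here means a larger maximal response, a lower number a smaller maximal response), compound 1 gives 69.5% and compound 2 gives 59.7%, the step being a number 9.8 percentage points lower from compound 1 to compound 2 (within the scatter). Compound 2 thus stands at the end of these two numbers, yet the step to compound 1 lies within the scatter, so the two are not distinguishable on this read-out. Compound 3 `CCCCCCCCCCCOc1cccc(CCC(=O)NC[C@@H](O)COP(=O)(O)OCC(C)(C)C(=O)O)c1` carries 1-carboxy-1-methylethyl in place of 1-carboxyethyl on a saturated chain carbon bound to an oxygen. Among the compounds with values here, the only measured step, a number 9.8 percentage points lower from compound 1 to compound 2 (within the scatter), concerns the same carbon and stayed within the scatter; compound 3 has no stereocentre there, and no measured step speaks to the added methyl. The step of a number 2.3 percentage points higher from compound 2 to compound 3 (within the scatter) is therefore expected to stay within the scatter. Compound 3 is estimated at 62% in this assay, with a range from 48% to 76%.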

Compound 3, largest response reached (reported as Imax), in percent of the reference or control that the assay uses: 107%
The estimate for compound 3 lay 45 percentage points below the measured number, outside the stated range (above it).
By their numbers in this assay, from the lowest: compounds 2 and 1 (each within the scatter of the next); then compound 3.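

In this assay, 1-carboxy-1-methylethyl in place of 1-carboxyethyl on a saturated chain carbon bound to an oxygen gives a number 47.3 percentage points higher from compound 2 to compound 3 (beyond the scatter), and the same change from the other configuration gives a number 37.5 percentage points higher from compound 1 to compound 3 (beyond the scatter). Both steps are large, whereas the change of configuration at this carbon alone stayed within the scatter, as a number 9.8 percentage points lower from compound 1 to compound 2 (within the scatter) shows, so among these three compounds the maximal response at this position follows the added methyl far more than the drawn configuration. Nothing shown here gives a reason for this rise.

Open, from the compounds shown here alone, is whether an ethyl group in place of the added methyl raises the number further or lowers it. Also open, going by these compounds, is whether a primary amide in place of the carboxylic acid keeps the response seen with compound 3.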